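The source may report more compounds than this note shows. Statements on the series, on what has been measured and on what is new or still open speak of the compounds shown alone.

Series notes, bromoacrylamide and amine analogues on a shared fused core.

Compound 1 `C=C(Br)C(=O)Nc1cccc(-c2cn3nc(-c4ccc(C)cc4)sc3n2)c1` is the reference point. Going by the values given here, in a functional assay on L1210 cells (Mus musculus) for inhibition, read by cell counting, with a stated time of 2 days (a lower number here means a stronger inhibitor, a higher number a weaker inhibitor), compound 1 gives 920 nM, the lowest of the two numbers so far. Compound 2 `COc1ccc(-c2csc3nc(-c4cccc(N)c4)cn23)cc1` carries an amine in place of the bromoacrylamide and a methoxy-bearing aryl on the core; in this assay compound 2 gives 19000 nM, a gap to compound 1 that lies beyond the scatter. Compound 3 `Nc1cccc(-c2cn3nc(-c4ccc(Cl)cc4)sc3n2)c1`, also an amine with a chloro-bearing aryl on the core, returns only a limit in this assay, >= 250000 nM. That sits at the limit of >= 250000 nM in this assay, at which 1 of the 3 values shown sits, so no number is known for compound 3.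

Among the compounds with values here, no pair among the measured compounds differs in one place, so the step to compound 4 `C=C(Br)C(=O)Nc1cccc(-c2cn3nc(Cc4ccccc4)sc3n2)c1` has no direct precedent. Compound 4 keeps the bromoacrylamide of compound 1 and differs only on the core, (benzyl in place of 4-methylphenyl on an aromatic carbon). A step of modest size, toward a higher number, is expected in this assay; the expected change is a 2.7-fold higher number from compound 1 to compound 4 (0.43 log units; beyond the scatter). For compound 4 the estimate in this assay is 2500 nM, with a range from 700 nM to 9000 nM.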

Compound 4, half-maximal inhibitory concentration: 3000 nM
For compound 4 the middle estimate is 1.2-fold (0.08 log units) below the measured one; the measured number falls inside the stated range.
By their numbers in this assay, from the lowest: compound 1; then compound 4; then compound 2. At a limit, above all of these: compound 3.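

Here the series gets its first single-place comparison: with the bromoacrylamide held fixed, benzyl in place of 4-methylphenyl on an aromatic carbon of the five-membered aromatic ring gives, in this assay, a 3.3-fold higher number from compound 1 to compound 4 (0.51 log units; beyond the scatter) as the size of the change at this position. The two groups have the same atoms, joined differently, so at this position a rearrangement alone, with no change in the counts of heavy atoms, donors or acceptors, is enough to move the number by a modest step. Nothing on hand measures any property that bears on this step, so it stays an observation without an assigned cause.

On these data alone, how a longer chain such as phenethyl, a plain phenyl or a phenyl bearing a carboxylic acid would behave at this position remains open, since benzyl and 4-methylphenyl are only two points there. As far as these compounds go, the contribution of the bromoacrylamide also remains open, since compound 2 and compound 3 differ from compound 1 in more than one place, and an amine paired with the 4-methylphenyl or benzyl core would be needed to isolate it.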